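Fluoro for Methyl on the Biaryl: Cytotoxicity Outlook

The source may hold more compounds than are shown below. What is called first, only, known or untested is meant among the compounds shown, and "the series" means these compounds.

Compound 1 `Cc1cc(-c2ccc(C#N)c(F)c2)ccc1Oc1ccnc(Nc2ccc(C#N)cc2)n1` gives > 296000 nM in a functional assay on MT4 cells (Homo sapiens) for cytotoxicity, read by MTT assay, with a stated time of 5 days (on this read-out higher numbers stand for lower toxicity in this test and lower numbers for higher toxicity in this test), a limit of the assay.
Compound 2 `Cc1cc(C#N)ccc1-c1ccc(Oc2ccnc(Nc3ccc(C#N)cc3)n2)c(F)c1` gives > 296000 nM in this assay, also a limit.
Compound 3 `N#Cc1ccc(Nc2nccc(Oc3ccc(-c4ccc(C#N)cc4)cc3Cl)n2)cc1` gives > 295000 nM in this assay, again a limit.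

None of the three measured compounds reaches a numerical value, so compound 2 stands level with its neighbours and none can be called more or less toxic. Compound 2 sits at the limit of > 296000 nM in this assay, at which 2 of the 3 values shown sit. Compound 3 sits at the limit of > 295000 nM in this assay, at which 1 of the 3 values shown sits. Compound 4 `N#Cc1ccc(Nc2nccc(Oc3ccc(-c4ccc(C#N)c(F)c4)cc3F)n2)cc1` differs from compound 2 in one place: 4-cyano-3-fluorophenyl in place of 4-cyano-2-methylphenyl on an aromatic carbon. With every value at a limit, no change beyond the scatter is expected in this assay. The expected step is a number no higher from compound 2 to compound 4 (the limit leaves the size open). Compound 4 is estimated at 296000 nM, between 150000 nM and 600000 nM, most likely reported once more as a limit.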

Compound 4, half-maximal cytotoxic concentration: > 294000 nM
Compound 4: no number, only a limit; the forecaster's own chance of this, stated with the estimate: 90%; the middle value does not contradict the limit.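

For the compounds shown here, compound 4, like compound 1 and compound 2, gives only a limit in this assay, so no step to compound 4 can be read from either. The compounds shown leave open whether fluoro in place of methyl changes cytotoxicity at all.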